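The source may report more compounds than this note shows. Statements on the series, on what has been measured and on what is new or still open speak of the compounds shown alone.

Measured compounds:
compound 1 `Cc1nc(N(C)C(=O)NC(=O)c2c(F)cccc2F)sc1C(=O)N/N=C/c1cccc(C(F)(F)F)c1` gives 31.6 ug/mL
compound 2 `COc1ccc(/C=N/NC(=O)c2sc(N(C)C(=O)NC(=O)c3c(F)cccc3F)nc2C)cc1` gives 22.7 ug/mL

In a functional assay on HepG2 cells (Homo sapiens) for inhibition, read by MTT assay, with a stated time of 72 h (a higher number here means a weaker inhibitor, a lower number a stronger inhibitor), compound 1 stands at the highest of the two numbers, yet the step of a 1.4-fold lower number from compound 1 to compound 2 (0.14 log units; within the scatter) lies within the scatter, so compound 1 and compound 2 cannot be told apart on these data. Compound 3 `Cc1nc(N(C)C(=O)NC(=O)c2c(F)cccc2F)sc1C(=O)N/N=C/c1cc(C(F)(F)F)cc(C(F)(F)F)c1` has not been measured. It differs from compound 1 by trifluoromethyl in place of hydrogen on an aromatic carbon, the new group sitting meta to a trifluoromethyl group already present. Going by the values given here, no measured step touches this position. Among the compounds with values here, the only step available, a 1.4-fold lower number from compound 1 to compound 2 (0.14 log units; within the scatter), exchanges the whole ring on the carbon with a double bond to nitrogen and stays within the scatter, which gives no reason to expect a movement beyond the scatter for a second trifluoromethyl group. Compound 3 is therefore expected to give 30 ug/mL, with a range from 12 ug/mL to 75 ug/mL. The expected step of a 1.1-fold lower number from compound 1 to compound 3 (0.02 log units; within the scatter) is small.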

Compound 3, half-maximal inhibitory concentration: 11.4 ug/mL
The estimate for compound 3 lay 2.6-fold (0.42 log units) above the measured number; the measured number lies below the stated range.
By their numbers in this assay, from the lowest: compounds 3, 2 and 1 (each within the scatter of the next, the first and the last beyond it).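

In this assay, adding the second trifluoromethyl group gives a 2.8-fold lower number from compound 1 to compound 3 (0.44 log units; beyond the scatter). This shows that a single substitution on this aromatic carbon, meta to a trifluoromethyl group, can move the number beyond the scatter, which the exchange of the whole ring in a 1.4-fold lower number from compound 1 to compound 2 (0.14 log units; within the scatter) did not show. The step is modest and rests on this one pair, and no measurement at hand bears on why the number moves.

The compounds shown leave open whether the change is specific to trifluoromethyl or would also follow with another group on this carbon, such as a chlorine atom, a methyl group or an amine. They also leave open whether this carbon would respond in the same way without the trifluoromethyl group already on the ring.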